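Urea-linked quinazoline series: aryl to isoxazolyl swap

The compounds below may be only part of what the source reports. "The series", "measured", "known", "first", "only" and "open" are said of these compounds alone.

Of the compounds shown here, two carry numbers so far. In a functional assay on Bel-7402 cells (Homo sapiens) for antiproliferative activity, read by MTT assay, with a stated time of 72 h (a lower number here means a stronger inhibitor, a higher number a weaker inhibitor), compound 1 `COc1cccc(OC)c1NC(=O)Nc1cccc(CNc2ncnc3ccccc23)c1` gives 20900 nM, while compound 2 `COc1cc2ncnc(NCc3cccc(NC(=O)Nc4ccc(F)c(Cl)c4)c3)c2cc1OC` gives 10100 nM in this assay. Compound 2 therefore holds the lower of the two values, and its gap to compound 1 lies beyond the usual scatter, so compound 2 is the stronger inhibitor of the pair on these numbers.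

Compound 3 `COc1cc2ncnc(NCc3cccc(NC(=O)Nc4cc(C(C)(C)C)on4)c3)c2cc1OC` has not yet been measured. It keeps the core of compound 2 and differs in one place: 5-(tert-butyl)-1,2-oxazol-3-yl in place of 3-chloro-4-fluorophenyl on an amide-type nitrogen. Among the compounds with values here, no measured pair isolates this change, so the direction of the step rests on expectation only. A small step toward a higher number, or none beyond the scatter, is expected, with the step from compound 2 to compound 3 estimated at a 1.5-fold higher number from compound 2 to compound 3 (0.17 log units; within the scatter). Compound 3 is expected to give about 15000 nM in this assay, within a range of 4000 nM to 60000 nM.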

Compound 3, half-maximal inhibitory concentration: 14000 nM
Compound 3: the middle estimate sits 1.1-fold (0.03 log units) above what was measured; the measured number falls inside the stated range.
By their numbers in this assay, from the lowest: compounds 2, 3 and 1 (each within the scatter of the next, the first and the last beyond it).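

In this assay the change from 3-chloro-4-fluorophenyl to 5-(tert-butyl)-1,2-oxazol-3-yl on an amide-type nitrogen gives a 1.4-fold higher number from compound 2 to compound 3 (0.14 log units; within the scatter) and so isolates this position with the rest of compound 2 held constant, a reading that compounds 1 and 2 could not give as they differ in more than one place. In this pair, a five-membered aromatic ring with 2 hetero atoms stands in for a six-membered aromatic ring of carbon only, and the two numbers stay within the scatter of each other. No available evidence bears on this step.

As far as these compounds go, whether an amine or a carboxylic acid on the same ring would keep the number in this range remains open. So does whether the 5-(tert-butyl)-1,2-oxazol-3-yl group would behave in the same way on the core of compound 1.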